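Ethyl in Place of Acid Hydrogen on a Shared Core

The source may report more compounds than this note shows. Statements on the series, on what has been measured and on what is new or still open speak of the compounds shown alone.

Compound 1 `O=C(O)/C=C/c1ccncc1-c1ccc2cc[nH]c2c1` is the starting point. In a functional assay on HCT-116 cells (Homo sapiens) for inhibition, read by MTT assay, with a stated time of 72 h (a lower number here means a stronger inhibitor of growth, a higher number a weaker inhibitor of growth), compound 1 gives only a limit, > 30000 nM, so no single number is known for it. That limit, (the limit of > 30000 nM in this assay, at which 1 of the 3 values shown sits), marks the weakest end of what has been measured. Compound 2 `CNC(=O)/C=C/c1ccncc1-c1ccc2c(cnn2C)c1`, built on a different core, gives 3480 nM in this assay. Compound 3 `O=C(O)COc1ccncc1-c1ccc2ccccc2c1` has no result in this assay; its entry reads "not determined" (no result reported).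

Compound 4 `CCOC(=O)/C=C/c1ccncc1-c1ccc2cc[nH]c2c1` differs from compound 1 by a single change, (ethyl in place of hydrogen on an oxygen next to a carbonyl group). Going by the values given here, no measured pair shows this same change, so its effect cannot be read from the data. Because compound 1 sits at the limit (the limit of > 30000 nM in this assay, at which 1 of the 3 values shown sits), compound 4 can hardly be weaker and any real change would show as stronger growth inhibition. The step from compound 1 to compound 4 is expected to be an at least 3.3-fold lower number from compound 1 to compound 4 (0.52 log units; beyond the scatter), a gain that is uncertain. Compound 4 is therefore estimated at 9000 nM in this assay, within a range from 2500 nM to 30000 nM.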

Compound 4, concentration for 50% growth inhibition: 2140 nM
Compound 4: middle estimate off by 4.2-fold (0.62 log units), on the high side; measured number outside the range, below it.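

Replacing hydrogen with ethyl on an oxygen next to a carbonyl group, which turns carboxy into ethoxycarbonyl, gives an at least 14-fold lower number from compound 1 to compound 4 (1.14 log units; beyond the scatter) in this assay. Going by these compounds alone, compound 1 is given only as a limit, so this step is a minimum and its full size stays unknown: the limit of > 30000 nM in this assay, at which 1 of the 4 values shown sits. This is the first comparison of two compounds that differ in one place, and it shows that growth inhibition in these cells responds strongly to what sits on this oxygen.

The compounds shown leave open whether ethyl itself matters or whether any group in place of the acid hydrogen would do, as a methyl group or a longer chain such as butyl on the same oxygen could tell. From the compounds shown here alone, whether this change gives a similar step on a different core also remains open.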